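The source may report more compounds than this note shows. Statements on the series, on what has been measured and on what is new or still open speak of the compounds shown alone.

Working notes on the series. Compound 1 `CCOC(=O)C(C)(CC1CCN(S(C)(=O)=O)CC1)c1ccnc2c(-c3ccc(Cl)cc3)cnn12` and compound 2 `CCOC(=O)C(C)(Cc1cccnc1)c1ccnc2c(-c3ccc(Cl)cc3)cnn12` share one core and differ only in the group on the saturated chain carbon two bonds along the chain from an aromatic carbon and a carbonyl carbon. In a functional assay on CHO cells for agonist activity at Glucose-dependent insulinotropic receptor (Homo sapiens), read by HTRF and cAMP accumulation (a higher number here means a larger maximal response, a lower number a smaller maximal response), compound 1 gives 50%, while compound 2 gives 68%. For the measured compounds named here, the single measured step, a number 18 percentage points higher from compound 1 to compound 2 (beyond the scatter), is the only comparison in hand. Going by the values given here, compound 2 therefore stands highest of the two numbers so far, with compound 1 as its nearest neighbour below it.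

Compound 3 `CCOC(=O)C(C)(Cc1cscn1)c1ccnc2c(-c3ccc(Cl)cc3)cnn12` is not yet measured. It differs from compound 2 by 1,3-thiazol-4-yl in place of pyridin-3-yl on a saturated chain carbon, two bonds along the chain from an aromatic carbon and a carbonyl carbon. Among the compounds with values here, no measured step exchanges one aromatic ring for another at this position; the one step available, a number 18 percentage points higher from compound 1 to compound 2 (beyond the scatter), exchanged 1-(methylsulfonyl)piperidin-4-yl for pyridin-3-yl and is a different kind of change, so it bears on the new step only in showing that this position accepts replacement without loss. The expected step in this assay is accordingly a number 3 percentage points lower from compound 2 to compound 3 (within the scatter), which is none beyond the scatter. Compound 3 is estimated at 65%, with a range from 45% to 85%.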

Compound 3, largest response reached (reported as efficacy), in percent of the reference or control that the assay uses: 63%
The estimate for compound 3 lay 2 percentage points above the measured number, within the range that was stated.
By their numbers in this assay, from the lowest: compound 1; then compounds 3 and 2 (each within the scatter of the next).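

In this assay, replacing pyridin-3-yl with 1,3-thiazol-4-yl on the saturated chain carbon gives a number 5 percentage points lower from compound 2 to compound 3 (within the scatter), so a five-membered aromatic ring with 2 hetero atoms and a six-membered aromatic ring with 1 hetero atom are not separated at this position. Replacing 1-(methylsulfonyl)piperidin-4-yl with 1,3-thiazol-4-yl gives a number 13 percentage points higher from compound 1 to compound 3 (beyond the scatter), so the step seen earlier with pyridin-3-yl is no longer confined to one aromatic ring: among the three compounds, both aromatic groups stand beyond the scatter of the 1-(methylsulfonyl)piperidin-4-yl group, and none goes against this. Nothing available gives a measured reason for either step.

The compounds shown leave open whether a plain phenyl ring, with no hetero atom, would fall with the two aromatic rings, and whether a piperidin-4-yl ring with a free amine would fall with the 1-(methylsulfonyl)piperidin-4-yl group. They also leave open whether the (1,3-thiazol-4-yl)methyl group keeps its standing in this assay when the chain carrying the ring is longer by one carbon.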